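Ester-to-benzylamide change at the core of compound 1

The source may hold more compounds than are shown below. What is called first, only, known or untested is meant among the compounds shown, and "the series" means these compounds.

Compound 1 `COC(=O)c1ccc2c(ccn2-c2ccc(NC(=O)c3ccc(Cl)c(C(F)(F)F)c3)cc2)n1` is the reference here. In a functional assay on A375P cells (Homo sapiens) for cytotoxicity, read by MTT assay (a lower number here means a stronger inhibitor, a higher number a weaker inhibitor), compound 1 gives 3000 nM, the lowest of the three numbers in hand. Compound 3 `COC(=O)c1ccc2c(ccn2-c2ccc(NC(=O)Nc3ccc(Cl)c(Cl)c3)cc2)n1` gives 3800 nM and compound 2 `COC(=O)c1ccc2c(ccn2-c2ccc(NC(=O)Nc3cccc(Cl)c3Cl)cc2)n1` gives 6400 nM. The step of a 1.3-fold higher number from compound 1 to compound 3 (0.10 log units; within the scatter) stays within the scatter, the step of a 2.1-fold higher number from compound 1 to compound 2 (0.33 log units; beyond the scatter) goes beyond it, and the step of a 1.7-fold lower number from compound 2 to compound 3 (0.23 log units; within the scatter) stays within it; all three steps vary the aryl group on the amide or urea carbonyl, not the ester.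

Compound 4 `O=C(Nc1ccc(-n2ccc3nc(C(=O)NCc4ccccc4)ccc32)cc1)c1ccc(Cl)c(C(F)(F)F)c1` differs from compound 1 by benzylamino in place of methoxy on a carbonyl carbon. For the measured compounds named here, no measured step touches this end of the molecule, so none of the three steps bears on the change directly. What the measured compounds do show is that this assay moves only modestly, at most a 2.1-fold higher number from compound 1 to compound 2 (0.33 log units; beyond the scatter), across the changes tried so far. Going by the values given here, with no step at the ester carbonyl to lean on, the expectation for compound 4 is kept near compound 1 with a wide range. The expected step of a 1.2-fold lower number from compound 1 to compound 4 (0.08 log units; within the scatter) is estimated to stay within the scatter. Compound 4 is estimated at 2500 nM, with a range from 600 nM to 10000 nM.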

Compound 4, half-maximal inhibitory concentration: 700 nM
Compound 4: middle estimate off by 3.6-fold (0.55 log units), on the high side, and the stated range covers the measured number.
By their numbers in this assay, from the lowest: compound 4; then compounds 1, 3 and 2 (each within the scatter of the next, the first and the last beyond it).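

Replacing methoxy with benzylamino on the carbonyl carbon shows that the ester end of the core of compound 1 also bears on this assay, with a 4.3-fold lower number from compound 1 to compound 4 (0.63 log units; beyond the scatter). This step is larger in printed size than the largest step from the aryl changes, a 2.1-fold higher number from compound 1 to compound 2 (0.33 log units; beyond the scatter), so the position accepts a swap from 2 heavy atoms to 8 and gives a lower number, not a loss. No measurement in hand explains the step.

The change brings in an aromatic ring and a hydrogen-bond donor together and removes the ester oxygen link, so the compounds shown do not separate the contribution of each; methylamino would keep the amide hydrogen without the ring, while the carboxylic acid and a longer phenylethylamino chain would test other ends of the range at this carbonyl carbon. From the compounds shown here alone, it also remains open whether benzylamino in place of methoxy gives a similar step on the urea compounds, compound 2 and compound 3, whose aryl groups differ from that of compound 1.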